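Azidocoumarin series: dropping the methoxy of compound 1

The source may hold more compounds than are shown below. What is called first, only, known or untested is meant among the compounds shown, and "the series" means these compounds.

Three compounds of this series have so far been run in a functional assay on MCF7 cells (Homo sapiens) for cytotoxicity, read by MTT assay, with a stated time of 24 h; a lower number here means a stronger inhibitor, a higher number a weaker inhibitor. Compound 1 `COc1cccc2cc(N=[N+]=[N-])c(=O)oc12` gives 31500 nM, the highest of the three numbers. Compound 3 `[N-]=[N+]=Nc1cc2cc(Cl)cc(Cl)c2oc1=O` gives 18600 nM, a number that lies within the scatter of compound 1. Compound 2 `NCCC(=O)N1Cc2ccccc2-c2nnn(-c3cc4cc(Br)ccc4oc3=O)c2-c2ccccc21` gives 10700 nM, and its gap to compound 1 lies beyond the scatter. Compound 4 `[N-]=[N+]=Nc1cc2ccccc2oc1=O` is the next compound to be run; relative to compound 1 the change is hydrogen in place of methoxy on an aromatic carbon. Among the measured compounds shown here, no measured pair differing in one place exists in this set, so the size of such a change has no precedent here. The step of a 1.3-fold lower number from compound 1 to compound 4 (0.10 log units; within the scatter) is expected to be small, with no change beyond the scatter in this assay. Compound 4 is estimated at 25000 nM, with a range from 10000 nM to 60000 nM.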

Compound 4, half-maximal inhibitory concentration: 26700 nM
Beside the measured number, compound 4's estimate is 1.1-fold (0.03 log units) below it; the measured number falls inside the stated range.
By their numbers in this assay, from the lowest: compounds 2, 3, 4 and 1 (each within the scatter of the next, the first and the last beyond it).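

Among the compounds shown here, the first pair that differs in one place gives this change a size: hydrogen in place of methoxy on an aromatic carbon yields a 1.2-fold lower number from compound 1 to compound 4 (0.07 log units; within the scatter) in this assay and so stays small. At this place, ortho to a fused ring, the methoxy can therefore be removed with no change beyond the scatter. No available data explain this result.

From the compounds shown here alone, whether an amine, a carboxylic acid or a longer alkoxy chain at this place would shift the number remains open. A single pair also leaves open whether the same change would stay this small on another core.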